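Compound 2 to compound 4: a changed group on the core

A few compounds are considered here, and "the series" means these few. Any claim that something is new, unique, unknown or untested is made for them only; others in the source may bear on it.

Measured so far in an ADME assay on BHK-21 cells (Mesocricetus auratus) for cytotoxicity, read by MTT assay, with a stated time of 72 h; a higher number here means that more compound is tolerated, a lower number that less compound is tolerated:
Compound 1 `NS(=O)(=O)c1ccc(N2N=C(c3ccccc3)CC2c2ccccc2F)cc1` gives 21000 nM
Compound 2 `Cc1ccccc1C1CC(c2ccc(OCc3ccccc3)cc2)=NN1c1ccc(S(N)(=O)=O)cc1` gives 20000 nM
Compound 3 `Cc1ccc(C2CC(c3ccccc3)=NN2c2ccc(S(N)(=O)=O)cc2)cc1` gives 7000 nM

Compound 2 at 20000 nM and compound 1 at 21000 nM lie within the scatter of each other, and compound 3 at 7000 nM stands lower than both.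

Compound 4 `NS(=O)(=O)c1ccc(N2N=C(c3ccc(OCc4ccccc4)cc3)CC2c2ccc(Cl)cc2)cc1` has not yet been measured. Its difference from compound 2 is 4-chlorophenyl in place of 2-methylphenyl on a saturated ring carbon, with 4-chlorophenyl in place of 2-methylphenyl on a saturated ring carbon.

Within the data shown here, one measured step bears on this change, a 3.0-fold lower number from compound 1 to compound 3 (0.48 log units; beyond the scatter), where 4-methylphenyl replaces 2-fluorophenyl at the same kind of carbon. Among the measured compounds shown here, it is a modest step and the only guide, since no measured compound carries 4-chlorophenyl. A drop of similar or somewhat smaller size is therefore expected in this assay, and the estimated move is a 2.2-fold lower number from compound 2 to compound 4 (0.35 log units; beyond the scatter) as an expectation only. For compound 4 the expected value is 9000 nM and the estimated range runs from 3500 nM to 22000 nM as the likely span.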

Compound 4, half-maximal cytotoxic concentration: 15000 nM
The estimate for compound 4 lay 1.7-fold (0.22 log units) below the measured number; the measured number falls inside the stated range.
By their numbers in this assay, from the lowest: compound 3; then compounds 4, 2 and 1 (each within the scatter of the next).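

In this assay, 4-chlorophenyl in place of 2-methylphenyl on the saturated ring carbon gives a 1.3-fold lower number from compound 2 to compound 4 (0.12 log units; within the scatter), so a change of aryl group at this position need not move the number beyond the scatter. The earlier step at the same kind of carbon, a 3.0-fold lower number from compound 1 to compound 3 (0.48 log units; beyond the scatter), had shown only a change that did, but it involves a different pair of groups and a different partner elsewhere on the core, so the two steps do not isolate a single effect. No measurement shown here accounts for the difference between the two steps.

As far as these compounds go, it remains open whether 4-methylphenyl and 4-chlorophenyl would give the same number on one unchanged background. Also open, from the compounds shown here alone, is whether a group other than a substituted phenyl on this carbon, such as a pyridine or a morpholine, would move the number beyond the scatter.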